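Acetyl for ethoxy on a core that shows only limits

The source may hold more compounds than are shown below. What is called first, only, known or untested is meant among the compounds shown, and "the series" means these compounds.

Compound 1 `CCOc1ccc(N/N=C2\CCC(C)n3c2ncc(C(=O)O)c3=O)cc1` is the reference. In a functional assay on the whole organism for inhibition, with Rattus norvegicus as the target (a lower number here means that less compound is needed, a higher number that more compound is needed for the effect), compound 1 gives > 100 umol/kg, which is a limit of the assay and not a number. Compound 2 `CCOc1ccc(N/N=C2\CC[C@@H](C)n3c2ncc(C(=O)O)c3=O)cc1` carries the same atoms and bonds with its ring stereocentre drawn R, and in this assay compound 2 gives > 100 umol/kg, again a limit. Compound 3 `CCOc1ccc(N/N=C2\CC[C@H](C)n3c2ncc(C(=O)O)c3=O)cc1` has that centre drawn S, and in this assay compound 3 gives > 100 umol/kg, also a limit. From the compounds shown here alone, the steps from compound 1 to compound 2 a step that the two limits leave unreadable from compound 1 to compound 2, from compound 1 to compound 3 a step that the two limits leave unreadable from compound 1 to compound 3 and from compound 2 to compound 3 a step that the two limits leave unreadable from compound 2 to compound 3 therefore cannot be read, because of the limit of > 100 umol/kg in this assay, at which 3 of the 3 values shown sit; their sizes stay unknown, and the drawn configurations (the fact that one of compounds 1 and 2 is drawn with a defined configuration and the other without, at the place where they differ), the fact that one of compounds 1 and 3 is drawn with a defined configuration and the other without, at the place where they differ and the fact that compounds 2 and 3 differ only in the configuration as drawn show no consequence that can be quantified.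

Compound 4 `CC(=O)c1ccc(N/N=C2\CCC(C)n3c2ncc(C(=O)O)c3=O)cc1` differs from compound 1 by acetyl in place of ethoxy on an aromatic carbon. Going by the values given here, none of the measured steps touches this position, so no step bears directly on the change. Since every measured value of the shared core sits at the limit, the expected step from compound 1 to compound 4 in this assay is a step that the limit leaves unreadable from compound 1 to compound 4, with no direction readable. Compound 4 is therefore estimated at 150 umol/kg in this assay, within 40 umol/kg to 1000 umol/kg, most likely again reported as a limit.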

Compound 4, dose for 50% inhibition: > 100 umol/kg
Compound 4: no number, only a limit; the forecaster's own chance of this, stated with the estimate: 70%; the middle value lies beyond the limit too.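

In this assay compound 4 gives > 100 umol/kg, which is a limit of the assay and not a number. The step from compound 1 to compound 4, acetyl in place of ethoxy, therefore cannot be read: the limit of > 100 umol/kg in this assay, at which 4 of the 4 values shown sit. The compounds shown leave open whether this exchange or the drawn configuration alters the dose needed for the effect at all.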